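Ring swap at the saturated ring carbon: phenyl to pyridyl

The source may hold more compounds than are shown below. What is called first, only, known or untested is meant among the compounds shown, and "the series" means these compounds.

Compound 1 `CC1=NC(C)=C(C(=O)O)C(c2ccccc2)/C1=C(\O)OC/C=C/c1ccccc1` gives 2000 nM in a functional assay on IMR-32 cells for inhibition of Voltage-dependent N-type calcium channel subunit alpha-1B (Homo sapiens), read by calcium flux; on this read-out lower numbers stand for stronger inhibition and higher numbers for weaker inhibition. Compound 2 `CC1=NC(C)=C(C(=O)O)C(c2cccc(I)c2)/C1=C(\O)OC/C=C/c1ccccc1` gives 1700 nM in this assay; the change from compound 1 to compound 2 is an iodo in place of hydrogen on an aromatic carbon, and the result is a 1.2-fold lower number from compound 1 to compound 2 (0.07 log units; within the scatter). Among the two measured compounds, compound 2 holds the lower number, but its gap to compound 1 is within the scatter, so the two are not separated.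

Compound 3 `CC1=NC(C)=C(C(=O)O)C(c2cccnc2)/C1=C(\O)OC/C=C/c1ccccc1` is not yet measured. Relative to compound 2 the difference is pyridin-3-yl in place of 3-iodophenyl on a saturated ring carbon. For the measured compounds named here, the only measured step, from compound 1 to compound 2, also alters the aromatic group on that saturated ring carbon and lies within the scatter; no step covers the exchange of a carbon ring for one holding a nitrogen. The step from compound 2 to compound 3 is therefore expected to be modest, a 1.5-fold higher number from compound 2 to compound 3 (0.17 log units; within the scatter), with wide uncertainty. For compound 3 the expected value in this assay is 2500 nM, in a range from 1000 nM to 6500 nM.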

Compound 3, half-maximal inhibitory concentration: 24000 nM
Compound 3: middle estimate off by 9.6-fold (0.98 log units), on the low side; measured number above the stated range.
By their numbers in this assay, from the lowest: compounds 2 and 1 (each within the scatter of the next); then compound 3.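

In this assay the aromatic group on the saturated ring carbon proves sensitive to change: pyridin-3-yl in place of 3-iodophenyl gives a 14-fold higher number from compound 2 to compound 3 (1.15 log units; beyond the scatter) and marks this exchange as large, and pyridin-3-yl in place of phenyl gives a 12-fold higher number from compound 1 to compound 3 (1.08 log units; beyond the scatter) and points the same way without any iodo involved. For the compounds shown here, compound 1 and compound 2 stay within the scatter of each other, so the iodo change left the two unseparated, whereas the swap of a carbon-only ring for one holding a nitrogen is the one change here that comes with a large step. Nothing at hand accounts for the size of this step.

Still open, from the compounds shown here alone, is whether a pyridin-4-yl group would carry a step of similar size. Equally open, going by these compounds, is whether an iodo or an amine on the pyridin-3-yl ring would alter the number for compound 3 24000 nM in either direction.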